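A Phenyl for Furan-2-yl in MRC5 Cells

This account rests on a few compounds, and the source may have more. Where it says the series, first, only, none or still open, it means among the compounds named here.

Values in an ADME assay on MRC5 cells (Homo sapiens), read by MTT assay, with a stated time of 72 h; on this read-out higher numbers stand for weaker inhibition and lower numbers for stronger inhibition:
- Compound 1 `C#Cc1cn([C@@H]2O[C@H](CO)[C@@H](O)[C@H]2O)c2ncnc(OC)c12`: > 100000 nM (a limit of the assay, not a number)
- Compound 2 `CSc1ncnc2c1c(-c1cccs1)cn2[C@@H]1O[C@H](CO)[C@@H](O)[C@H]1O`: > 100000 nM (a limit of the assay, not a number)
- Compound 3 `CNc1ncnc2c1c(-c1ccco1)cn2[C@@H]1O[C@H](CO)[C@@H](O)[C@H]1O`: 90800 nM

For the measured compounds named here, compound 3, at 90800 nM, holds the only actual number in this small set. The results for compound 1 and compound 2 are not numbers but (the limit of > 100000 nM in this assay, at which 2 of the 3 values shown sit). Going by the values given here, no two of the three compounds differ in one place only, so this assay offers no measured step to serve as a guide.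

The next compound to be tested is compound 4 `CNc1ncnc2c1c(-c1ccccc1)cn2[C@@H]1O[C@H](CO)[C@@H](O)[C@H]1O`, which keeps the shared core of compound 3 and its methylamino group. The change is at one place, with phenyl in place of furan-2-yl on an aromatic carbon.

Among the compounds with values here, with no measured step to draw on, the expectation rests on compound 3 at 90800 nM, and no shift beyond the scatter is expected in either direction. The expected change is a 1.1-fold lower number from compound 3 to compound 4 (0.03 log units; within the scatter). The result may also turn out to be only a limit of the assay. For compound 4 the estimate is 85000 nM, with an expected range from 35000 nM to 180000 nM.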

Compound 4, half-maximal inhibitory concentration: > 100000 nM
Compound 4 gave a limit, no number; the forecaster's own chance of this, stated with the estimate: 50%; middle value at least 1.1-fold (0.07 log units) from the limit.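

In this assay, for the compounds shown here, the change from furan-2-yl to phenyl on this aromatic carbon, with the methylamino group and the shared core kept, gives the only measured step in the set: an at least 1.1-fold higher number from compound 3 to compound 4 (0.04 log units; that floor lies within the scatter). The result for compound 4 is a limit of the assay and not a number, so the step has a floor but no known size, and the change may or may not go beyond the scatter. What the step adds is that a six-membered aromatic ring of carbon only at this place yields no number in this assay, and the limit now covers most of the set: the limit of > 100000 nM in this assay, at which 3 of the 4 values shown sit.

Going by these compounds alone, compound 3, at 90800 nM, still holds the only actual number, so it remains open how far phenyl and furan-2-yl truly differ here. Also open, as far as these compounds go, is how this place responds to groups of another kind, such as an amine or a carboxylic acid on the phenyl ring, or an ethyl chain in place of the aromatic ring, and whether the same change reads alike with a methylthio group in place of the methylamino group.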